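Methoxy for methyl on the tert-butyl group

The source may report more compounds than this note shows. Statements on the series, on what has been measured and on what is new or still open speak of the compounds shown alone.

Compound 2 `CC(C)(C)[C@@H](O)C(=O)N1C[C@H]2C[C@H]2[C@H]1C(=O)NCc1cc(Cl)ccc1-n1cnnn1` gives 3.8 10^-6 cm/s in an ADME assay on Caco-2 cells (Homo sapiens) for permeability, read by LC-MS, in the apical to basolateral direction, with a stated time of 60 min, at pH 6.5 (a lower number here means that the compound crosses the layer more slowly, a higher number that the compound crosses the layer faster), the lower of the two measured values; compound 1 `CCCC[C@@H](O)C(=O)N1C[C@H]2C[C@H]2[C@H]1C(=O)NCc1cc(Cl)ccc1-n1cnnn1` gives 33 10^-6 cm/s. Among the compounds with values here, the single measured step, an 8.7-fold lower number from compound 1 to compound 2 (0.94 log units; beyond the scatter), exchanges one whole alkyl group for another and does not match the change to compound 3 `COC(C)(C)[C@@H](O)C(=O)N1C[C@H]2C[C@H]2[C@H]1C(=O)NCc1cc(Cl)ccc1-n1cnnn1`, which is methoxy in place of methyl on a saturated chain carbon bound to three saturated chain carbons. Within the data shown here, no measured step bears on this change directly. The change is expected to move compound 3 only slightly, if at all, perhaps a small decrease, a 1.3-fold lower number from compound 2 to compound 3 (0.10 log units; within the scatter). Compound 3 is estimated at 3 10^-6 cm/s, with a range from 1.2 10^-6 cm/s to 8 10^-6 cm/s.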

Compound 3, apparent permeability: 3.5 10^-6 cm/s
The estimate for compound 3 lay 1.2-fold (0.07 log units) below the measured number; the range from low to high includes it.
By their numbers in this assay, from the lowest: compounds 3 and 2 (each within the scatter of the next); then compound 1.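

In this assay, methoxy in place of methyl on a saturated chain carbon bound to three saturated chain carbons gives a 1.1-fold lower number from compound 2 to compound 3 (0.04 log units; within the scatter) and so leaves compound 3 level with compound 2. The gap to the butyl group also remains, with a 9.4-fold lower number from compound 1 to compound 3 (0.97 log units; beyond the scatter) for the 1-methoxy-1-methylethyl group. Nothing available here explains either step.

On these data alone, whether ethoxy or an amine on the same carbon would also stay within the scatter of compound 2 remains open. So does whether any branched group here can reach the number of compound 1.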